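A few compounds are considered here, and "the series" means these few. Any claim that something is new, unique, unknown or untested is made for them only; others in the source may bear on it.

Measured in an ADME assay on L1210/0 cells (Mus musculus) for cytotoxicity, with a stated time of 48 h; on this read-out higher numbers stand for weaker inhibition and lower numbers for stronger inhibition:
- Compound 1 `O=c1[nH]c(=O)n([C@H]2C[C@H](O)[C@@H](CO)O2)cc1C#CCO`: > 200000 nM
- Compound 2 `CCCC#Cc1cn([C@H]2C[C@H](O)[C@@H](CO)O2)c(=O)[nH]c1=O`: > 200000 nM

Compound 1 gives > 200000 nM, which is a limit and not a number. As far as these compounds go, compound 2 also gives a limit, > 200000 nM, so its true position is unknown. Compound 3 `CC#Cc1cn([C@H]2C[C@H](O)[C@@H](CO)O2)c(=O)[nH]c1=O` differs from compound 2 in one place: hydrogen in place of ethyl on a saturated chain carbon bound to a triple-bonded carbon. The two measured compounds share (the limit of > 200000 nM in this assay, at which 2 of the 2 values shown sit). Within the data shown here, the only measured step touching this carbon is a step that the two limits leave unreadable from compound 1 to compound 2, so it offers no size to carry over. Any expected change is therefore small, towards stronger inhibition, and the expected step is an at least 1.3-fold lower number from compound 2 to compound 3 (0.12 log units; that floor lies within the scatter). Compound 3 is estimated at 150000 nM, with an expected range from 20000 nM to 400000 nM.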

Compound 3, half-maximal inhibitory concentration: > 200000 nM
Compound 3: only a limit was reported; the forecaster's own chance of this, stated with the estimate: 55%; middle value at least 1.3-fold (0.12 log units) from the limit.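

No step can be read among compound 1, compound 2 and compound 3, because each gives only a limit and not a number: the limit of > 200000 nM in this assay, at which 3 of the 3 values shown sit. As far as these compounds go, whether changing the group on the chain alters cytotoxicity at all stays open, as does how far each true value lies from that limit.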